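The Same Acetyl Change, Made Twice

The compounds below may be only part of what the source reports. "The series", "measured", "known", "first", "only" and "open" are said of these compounds alone.

Three compounds have been measured in a functional assay on PC-12 cells (Rattus norvegicus) for cytotoxicity, read by MTT assay, with stated times of 3 h and 2 h, tested at 20 uM; on this read-out higher numbers stand for a stronger effect at the one concentration tested and lower numbers for a weaker effect:

compound 1 `O=C(CCCCC1CCSS1)NCc1cn(CCCOc2ccc3ccc(=O)oc3c2)nn1` gives 42.2%
compound 2 `CC(=O)c1cc2ccc(OCCCn3cc(CNC(=O)CCCCC4CCSS4)nn3)cc2oc1=O` gives 39.8%
compound 3 `O=C(CCCCC1CCSS1)NCc1cn(CCCCCOc2ccc3ccc(=O)oc3c2)nn1` gives 78.5%

Compound 2 differs from compound 1 by acetyl in place of hydrogen on an aromatic carbon, and that change gave a number 2.4 percentage points lower from compound 1 to compound 2 (within the scatter). Compound 3 stands highest of the three, beyond the scatter from both compound 1 and compound 2. How the core of compound 3 differs from that of compound 1 is not broken down here.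

Among the measured compounds shown here, compound 4 `CC(=O)c1cc2ccc(OCCCCCn3cc(CNC(=O)CCCCC4CCSS4)nn3)cc2oc1=O` differs from compound 3 by acetyl in place of hydrogen on an aromatic carbon, the same change in the same place as the one from compound 1 to compound 2. Because that earlier step was a number 2.4 percentage points lower from compound 1 to compound 2 (within the scatter), compound 4 is expected to stay close to compound 3, with an estimated step of a number 2.5 percentage points lower from compound 3 to compound 4 (within the scatter). Compound 4 is estimated at 76%, between 62% and 90%.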

Compound 4, a percentage reported as activity, at one concentration (the size of the read-out at that concentration, not a potency): 20.7%
The estimate for compound 4 lay 55.3 percentage points above the measured number; measured number below the stated range.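

Acetyl in place of hydrogen on an aromatic carbon gave a number 57.8 percentage points lower from compound 3 to compound 4 (beyond the scatter) in this assay. The size of this change therefore did not carry over from one core to the other in this series: the same change on two cores in this assay, a number 2.4 percentage points lower (within the scatter) from compound 1 to compound 2 and a number 57.8 percentage points lower (beyond the scatter) from compound 3 to compound 4, 55.4 percentage points apart, beyond the scatter of two such steps This does not show why the two steps differ, and two pairs cannot tell how the change would behave on any further core.

The compounds shown leave open how an amine or a carboxylic acid in place of the acetyl would behave on these two cores. They also leave open how large the acetyl step would be on a core with a longer chain.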